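Ethoxy replacing methyl on the coumarin-side aromatic carbon

A few compounds are considered here, and "the series" means these few. Any claim that something is new, unique, unknown or untested is made for them only; others in the source may bear on it.

Within the data shown here, compound 2 `COc1ccc(/C=C/c2cc(OC)cc(OC)c2/C=C/C(=O)c2cc3cccc(C)c3oc2=O)cc1` gives 20000 nM in an assay on isolated protein for inhibition of Amine oxidase [flavin-containing] B (Homo sapiens), read by fluorescence, with a stated time of 15 min (on this read-out lower numbers stand for stronger inhibition and higher numbers for weaker inhibition), and stands as the higher of the two numbers so far; its nearest neighbour is compound 1 `COc1ccc(/C=C/c2cc(OC)cc(OC)c2/C=C/C(=O)c2cc3ccccc3oc2=O)cc1`, which in this assay gives 9170 nM. Among the measured compounds shown here, the one step measured, a 2.2-fold higher number from compound 1 to compound 2 (0.34 log units; beyond the scatter), is modest but beyond the scatter, so a substituent put on this aromatic carbon in place of hydrogen has been accompanied by a weaker number.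

Compound 3 `CCOc1cccc2cc(C(=O)/C=C/c3c(/C=C/c4ccc(OC)cc4)cc(OC)cc3OC)c(=O)oc12` carries the change (ethoxy in place of methyl on an aromatic carbon). For the measured compounds named here, no step swaps one substituent for another at this position; the only step that bears on it is the one from compound 1 to compound 2, which came with a modest weakening when the position was first substituted. On that basis a further modest move toward a higher number, or no move beyond the scatter, is expected.

Compound 3 is therefore expected to give about 25000 nM in this assay, with a plausible range of 9000 nM to 70000 nM. The expected step is a 1.3-fold higher number from compound 2 to compound 3 (0.10 log units; within the scatter).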

Compound 3, half-maximal inhibitory concentration: > 60000 nM
Compound 3 was reported as a limit; the forecaster's own chance of this, stated with the estimate: 15%; at least 2.4-fold (0.38 log units) between middle value and limit.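

In this assay, the swap of one substituent for another on this aromatic carbon came with an at least 3.0-fold higher number from compound 2 to compound 3 (0.47 log units; beyond the scatter), and the same group measured against the unsubstituted compound came with an at least 6.5-fold higher number from compound 1 to compound 3 (0.81 log units; beyond the scatter). Across the three compounds the number climbs at each step from hydrogen to methyl to ethoxy, and none of them goes against that order, which means the weaker number seen with methyl is not confined to methyl and extends to a second, larger substituent on this carbon. Compound 3 is reported as a limit and not as a number, which makes both of these steps lower bounds whose true size stays unknown: the limit of > 60000 nM in this assay, at which 1 of the 3 values shown sits.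

Ethoxy differs from methyl both in its chain and in the oxygen attached to the aromatic carbon, and these compounds cannot tell which of the two goes with the higher number. A hydroxyl, a fluorine or an amine on this carbon would bear on that question and on whether any group here can match hydrogen, and the three compounds leave both points open.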